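The compounds below may be only part of what the source reports. "The series", "measured", "known", "first", "only" and "open" are said of these compounds alone.

Measured compounds:
compound 1, `COc1cc(C(=O)O)ccc1OCCCCOc1ccc(C(=O)C(C)C)c(O)c1C` — 73.1%
compound 2, `Cc1c(OCCCCOc2ccc(C(=O)O)cc2)ccc(C(=O)CC2CCCC2)c1O` — 82.6%
compound 3, `Cc1c(OCCCCOc2ccc(C(=O)O)cc2)ccc(C(=O)CC2CCCC2)c1C` — 16.2%

In an assay on HEK293 cells for positive allosteric modulation of metabotropic glutamate receptor 2 (Rattus norvegicus), read by thallium flux, with a stated time of 2.5 min (on this read-out lower numbers stand for smaller maximal responses and higher numbers for larger maximal responses), compound 2 has the highest number of the three, although compound 1 lies within the usual scatter of it. Going by the values given here, the only measured step, a number 66.4 percentage points lower from compound 2 to compound 3 (beyond the scatter), concerns a change at a different part of the molecule and says nothing about the change considered here. Compound 4, `COc1ccc(C(=O)O)cc1OCCCCOc1ccc(C(=O)CC2CCCC2)c(O)c1C`, differs from compound 2 in one place: 5-carboxy-2-methoxyphenyl in place of 4-carboxyphenyl on an oxygen on a saturated carbon. Among the compounds with values here, no measured step covers this exchange. Compound 1 carries the same 5-carboxy-2-methoxyphenyl, but it also differs from compound 2 elsewhere. The value of compound 1 in this assay, 73.1%, therefore only suggests that the group is tolerated. A step of no more than the scatter is therefore expected, a number 6.6 percentage points lower from compound 2 to compound 4 (within the scatter), and compound 4 is estimated at 76%, between 58% and 94%.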

Compound 4, largest response reached (reported as percent of maximum), in percent of the reference or control that the assay uses: 91.8%
Beside the measured number, compound 4's estimate is 15.8 percentage points below it; measured number inside the range.
By their numbers in this assay, from the lowest: compound 3; then compounds 1, 2 and 4 (each within the scatter of the next, the first and the last beyond it).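

In this assay, 5-carboxy-2-methoxyphenyl in place of 4-carboxyphenyl on this oxygen can now be read directly: a number 9.2 percentage points higher from compound 2 to compound 4 (within the scatter). Before this, the group appeared only in compound 1, which also differs elsewhere; it is now shown to be tolerated on the core of compound 2. Nothing shown gives a reason for this result.

Compound 4 does not separate the effect of the methoxy group from that of the new arrangement of the carboxy group. On these data alone, whether a tetrazole or an amide could replace the carboxylic acid on this ring also stays open.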